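Series notes: the step from compound 2 to compound 3

The source may report more compounds than this note shows. Statements on the series, on what has been measured and on what is new or still open speak of the compounds shown alone.

Measured so far:
Compound 1 `COc1ccc(C(=O)/C=C/c2ccc(Br)cc2)c2c1C=CC(C)(C)O2` in a functional assay on HT-29 cells (Homo sapiens) for antiproliferative activity, read by MTT assay, with a stated time of 24 h (a higher number here means a weaker inhibitor, a lower number a stronger inhibitor), gives > 10000 nM, a limit of the assay.
Compound 2 `COc1ccccc1/C=C/C(=O)c1ccc(OC)c2c1OC(C)(C)C=C2` in this assay gives > 10000 nM, a limit of the assay.

Going by the values given here, compound 2 stands on no number at all; its value is a limit, and the one other value shown is a limit too. The change from compound 1 to compound 2 is therefore a step that the two limits leave unreadable from compound 1 to compound 2; it cannot be read. Among the compounds with values here, both compounds sit at the limit of > 10000 nM in this assay, at which 2 of the 2 values shown sit, so no measured step gives a size or a direction to work from.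

Compound 3 `COc1ccc(C(=O)/C=C/c2ccc(O)c(Br)c2)c2c1C=CC(C)(C)O2` differs from compound 2 in one place: 3-bromo-4-hydroxyphenyl in place of 2-methoxyphenyl on a double-bonded chain carbon bound to a double-bonded chain carbon. Within the data shown here, no measured step bears on this change; the only pair that alters the same position leaves its step unreadable. With nothing to carry over, the expectation in this assay is that compound 3 most likely also returns a limit, and the estimated step from compound 2 to compound 3 is a step that the limit leaves unreadable from compound 2 to compound 3, with no direction claimed. For compound 3 the estimate in this assay is 15000 nM, ranging from 3000 nM to 60000 nM.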

Compound 3, half-maximal inhibitory concentration: > 10000 nM
Compound 3: only a limit was reported; the forecaster's own chance of this, stated with the estimate: 70%; the middle value does not contradict the limit.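

Going by these compounds alone, compound 3 also returns only a limit in this assay, so no step among compound 1, compound 2 and compound 3 can be read, in size or direction: (the limit of > 10000 nM in this assay, at which 3 of the 3 values shown sit). The compounds shown leave open which change on the double-bonded chain carbon, if any, would give a measurable value in this assay rather than a limit.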